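Pyridyl for Fluorophenyl: Cytotoxicity Outlook for Compound 4

The source may report more compounds than this note shows. Statements on the series, on what has been measured and on what is new or still open speak of the compounds shown alone.

Measured compounds:
- compound 1, `COc1nc(-c2cccc(F)c2)ccc1[C@@H](c1ccccc1)[C@@](O)(CCN(C)C)c1cccc2ccccc12`: 62.8 ug/mL
- compound 2, `COc1ncc(-c2ccccc2)cc1[C@@H](c1ccccc1)[C@@](O)(CCN(C)C)c1cccc(F)c1F`: 28.1 ug/mL
- compound 3, `COc1nc(-c2ccccc2F)ccc1[C@@H](c1ccccc1)[C@@](O)(CCN(C)C)c1cccc2ccccc12`: "nd" (no result reported)

In a toxicity assay on HeLa cells (Homo sapiens) for cytotoxicity (on this read-out lower numbers stand for higher toxicity in this test and higher numbers for lower toxicity in this test), compound 1 gives 62.8 ug/mL and compound 2 gives 28.1 ug/mL. For compound 3 the entry in this assay reads "nd" (no result reported); no number exists, so compound 3 cannot be placed on the scale set by compound 1 and compound 2.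

Compound 4, `COc1nc(-c2ccncc2)ccc1[C@@H](c1ccccc1)[C@@](O)(CCN(C)C)c1cccc2ccccc12`, differs from compound 3 in one place: pyridin-4-yl in place of 2-fluorophenyl on an aromatic carbon. The 2-fluorophenyl leaves and a pyridin-4-yl enters on an aromatic carbon, next to the ring nitrogen, meta to the methoxy group and para to the large group. For the measured compounds named here, no measured pair shows this change, so its size in this assay is not known from the data. Since compound 1 and compound 2 both lie in a narrow band of this assay, the expectation is that the change brings no step beyond the usual scatter, in either direction.

Compound 4 is accordingly estimated in this assay at 45 ug/mL, with an expected range from 18 ug/mL to 110 ug/mL.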

Compound 4, half-maximal cytotoxic concentration: 9.6 ug/mL
For compound 4 the middle estimate is 4.7-fold (0.67 log units) above the measured one, and the stated range ends above it.
By their numbers in this assay, from the lowest: compound 4; then compound 2; then compound 1.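

In this assay, the aromatic carbon next to the ring nitrogen proves sensitive to what it carries: pyridin-4-yl in place of 3-fluorophenyl gives a 6.5-fold lower number from compound 1 to compound 4 (0.82 log units; beyond the scatter), a step beyond the scatter toward higher toxicity in this test. The change named for compound 4, from 2-fluorophenyl, cannot be read as a step, as compound 3 has no number, so the 3-fluorophenyl of compound 1 is the only measured reference at this position. Nothing at hand accounts for the size of this step.

The compounds shown do not separate the loss of the fluorine from the arrival of the ring nitrogen, which a plain phenyl or a pyridin-3-yl at this position would address. As far as these compounds go, how an aminomethyl group or a carboxylic acid on that ring would read in this assay also remains open.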